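Replacing cyclopropyl with 2-aminophenyl on compound 3

This account rests on a few compounds, and the source may have more. Where it says the series, first, only, none or still open, it means among the compounds named here.

Of the compounds shown here, three have been measured so far: compound 1 (`CC(C)c1nc2cc(Cl)c(Cl)cc2[nH]1`), compound 2 (`CC(C)n1c(C(F)(F)F)nc2cc(Cl)c(Cl)cc21`) and compound 3 (`FC(F)(F)c1nc2cc(Cl)c(Cl)cc2n1CC1CC1`). In a functional assay on MCF7 cells (Homo sapiens) for cytotoxicity, read by MTT assay, with a stated time of 48 h (on this read-out higher numbers stand for weaker inhibition of growth and lower numbers for stronger inhibition of growth), compound 1 gives 57000 nM, compound 2 gives 70500 nM and compound 3 gives 60200 nM. Compound 3 thus stands among three numbers that all lie within the usual scatter of one another, so no order can be drawn among them.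

The next structure is compound 4 (`Nc1ccccc1Cn1c(C(F)(F)F)nc2cc(Cl)c(Cl)cc21`), which carries 2-aminophenyl in place of cyclopropyl on a saturated chain carbon bound to an aromatic nitrogen. Among the measured compounds shown here, the only measured step that bears on this place is a 1.2-fold lower number from compound 2 to compound 3 (0.07 log units; within the scatter). For the measured compounds named here, that single step within the scatter is thin guidance, since no measured compound carries an aromatic ring here. Resting on compound 3 at 60200 nM and on that small step, the expectation in this assay is for no change beyond the scatter, with a slight lean toward a lower number. The expected change is a 1.5-fold lower number from compound 3 to compound 4 (0.18 log units; within the scatter). The estimate for compound 4 is 40000 nM, with an expected range from 14000 nM to 90000 nM.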

Compound 4, concentration for 50% growth inhibition: 55600 nM
The estimate for compound 4 lay 1.4-fold (0.14 log units) below the measured number; the range from low to high includes it.
By their numbers in this assay, from the lowest: compounds 4, 1, 3 and 2 (each within the scatter of the next).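

In this assay, 2-aminophenyl in place of cyclopropyl on a saturated chain carbon bound to an aromatic nitrogen gives a 1.1-fold lower number from compound 3 to compound 4 (0.03 log units; within the scatter), so this change does not separate the two compounds. The earlier step at this place exchanged only isopropyl and cyclopropylmethyl, whereas this one brings in a six-membered aromatic ring with 1 hydrogen-bond donor and 7 heavy atoms in place of 3, and the result still stays within the scatter. The position therefore accepts a quite different group without a readable shift in this read-out, although no measurement is at hand that could account for this.

The compounds shown leave open whether anything placed here can move the number beyond the scatter, for instance a carboxylic acid or a longer alkyl chain on the same carbon. They also cannot separate the part played by the ring from that of its amine, a question that a plain phenyl group in place of 2-aminophenyl would address in this assay.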